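Iodo in place of fluoro: compound 2 to compound 3

This account rests on a few compounds, and the source may have more. Where it says the series, first, only, none or still open, it means among the compounds named here.

Of the compounds shown here, two have been measured so far in an ADME assay on microsomes from liver (Canis lupus familiaris) for metabolic stability, read by LC-MS, using NADPH, with a stated time of 30 min, tested at 1 uM; a lower number here means that less of the compound is left, a higher number that more of the compound is left. Compound 1 `C=CC(=O)Nc1cc(Nc2ncc(I)c(Nc3ccccc3S(=O)(=O)N(C)C)n2)c(OC)cc1N(C)CCN(C)C` gives 35%, and compound 2 `C=CC(=O)Nc1cc(Nc2ncc(F)c(Nc3ccccc3S(=O)(=O)C(C)C)n2)c(OC)cc1N(C)CCN(C)C` gives 27%. These two numbers lie within the scatter of each other, which is where compound 2 stands on the present data.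

Compound 3 `C=CC(=O)Nc1cc(Nc2ncc(I)c(Nc3ccccc3S(=O)(=O)C(C)C)n2)c(OC)cc1N(C)CCN(C)C` is not yet measured. It follows from compound 2 by one change, iodo in place of fluoro on an aromatic carbon. Among the measured compounds shown here, no measured step that changes a single place is available to size this change. For the measured compounds named here, the only guide is the spread of the two measured values, and compound 1, which also bears iodo, gives 35% in this assay. No step beyond the scatter is therefore expected, and no firm direction can be assigned. The estimated step of a number 3 percentage points higher from compound 2 to compound 3 (within the scatter) is expected to remain within the scatter. For compound 3 the estimated value is 30%, with an expected range from 15% to 46%.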

Compound 3, percent of the compound remaining: 19%
The estimate for compound 3 lay 11 percentage points above the measured number, within the range that was stated.
By their numbers in this assay, from the lowest: compounds 3, 2 and 1 (each within the scatter of the next, the first and the last beyond it).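

Among the compounds shown here, the first single-place step at this carbon, iodo in place of fluoro on an aromatic carbon, reads a number 8 percentage points lower from compound 2 to compound 3 (within the scatter) in this assay; with isopropyl on the sulfonyl sulfur, the two halogens are therefore not told apart here, and this place, ortho and para to large groups, carries either one without a resolved step. For the compounds shown here, the only step beyond the scatter lies elsewhere in the molecule: with iodo held fixed, isopropyl in place of dimethylamino on a sulfonyl sulfur gives a number 16 percentage points lower from compound 1 to compound 3 (beyond the scatter), a modest step that points to the sulfonyl substituent rather than the halogen as the more telling place so far in this small set. No measurement at hand bears on why either step has the size it has.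

The compounds shown leave open whether chloro, bromo or a nitrile on this carbon would stay on the same level as iodo and fluoro. They also leave open whether the step between isopropyl and dimethylamino on the sulfonyl sulfur keeps its size with fluoro in place of iodo, and how a methyl group or a morpholine on that sulfur would read.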